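Triazole substituent removal in the butenolide series

The source may report more compounds than this note shows. Statements on the series, on what has been measured and on what is new or still open speak of the compounds shown alone.

Measured compounds in a functional assay on HeLa cells (Homo sapiens) for antiproliferative activity, read by MTT assay, with a stated time of 72 h; on this read-out lower numbers stand for stronger inhibition and higher numbers for weaker inhibition:
compound 1 `Cc1ccc(S(=O)(=O)NCc2cn(C[C@H](O)[C@H]3OC(=O)C(OCc4ccccc4)=C3OCc3ccccc3)nn2)cc1` gives 14400 nM
compound 2 `O=C1O[C@H]([C@@H](O)Cn2cc(CNS(=O)(=O)c3ccc(Cl)cc3)nn2)C(OCc2ccccc2)=C1OCc1ccccc1` gives 13600 nM
compound 3 `CCCCCCCCCCc1cn(C[C@H](O)[C@H]2OC(=O)C(OCc3ccccc3)=C2OCc2ccccc2)nn1` gives 22900 nM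

All three share the same core and differ only in the group on the five-membered aromatic ring with 3 nitrogen. The step of a 1.1-fold lower number from compound 1 to compound 2 (0.02 log units; within the scatter) shows that chloro in place of methyl on an aromatic carbon leaves the read-out unchanged. Compound 3 carries the highest of the three numbers, but its step from compound 1, a 1.6-fold higher number from compound 1 to compound 3 (0.20 log units; within the scatter), and its step from compound 2, a 1.7-fold higher number from compound 2 to compound 3 (0.23 log units; within the scatter), are both within the scatter, so no order among the three can be drawn.

Compound 4 `O=C1O[C@H]([C@@H](O)Cn2ccnn2)C(OCc2ccccc2)=C1OCc1ccccc1` follows from compound 3 by hydrogen in place of decyl on an aromatic carbon. The two steps that touch the same ring position, from compound 1 and from compound 2 to compound 3, swapped one large group for another and moved the number by little; none removed the group altogether. Going by the values given here, with no step that bears directly on this change, the expectation for compound 4 is a number near that of compound 3 or somewhat higher, with wide uncertainty. The expected step is a 1.4-fold higher number from compound 3 to compound 4 (0.15 log units; within the scatter). Compound 4 is therefore estimated at 32000 nM, within a range of 12000 nM to 90000 nM.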

Compound 4, half-maximal inhibitory concentration: > 100000 nM
Compound 4 ended at the assay's limit (the forecaster's own chance of this, stated with the estimate: 25%); at least 3.1-fold (0.49 log units) between middle value and limit.
By their numbers in this assay, from the lowest: compounds 2, 1 and 3 (each within the scatter of the next). At a limit, above all of these: compound 4.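

In this assay, compound 4 stands at a limit of the assay and not at a number: the limit of > 100000 nM in this assay, at which 1 of the 4 values shown sits. Taking the group off this aromatic carbon altogether gives the first steps in the series that lie beyond the scatter, whichever group leaves: an at least 4.3-fold higher number from compound 3 to compound 4 (0.64 log units; beyond the scatter), an at least 7.3-fold higher number from compound 2 to compound 4 (0.86 log units; beyond the scatter) and an at least 6.9-fold higher number from compound 1 to compound 4 (0.84 log units; beyond the scatter). The earlier exchanges between decyl and the two sulfonylamino-bearing groups stayed within the scatter, so among these four compounds the read-out hardly distinguishes which of the three groups sits here, yet it does distinguish any of them from hydrogen.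

Going by these compounds, how much of a group this carbon needs remains open: a methyl, a butyl chain or a simple aminomethyl group could give a number close to those of compounds 1, 2 and 3 or could fall at the limit with compound 4. Since compound 4 has only a limit, the full size of its steps is also unknown, and the series gives no reason for the loss.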